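From propyl to 4-cyanophenyl in compound 4

A few compounds are considered here, and "the series" means these few. Any claim that something is new, unique, unknown or untested is made for them only; others in the source may bear on it.

Three compounds share one core and differ in the group on the ring amine nitrogen: compound 1 `CN1CCN(c2ccc(-c3cc4c(N5CCN(S(=O)(=O)/C=C/c6ccccc6)CC5)ncnc4s3)cc2)CC1`, compound 2 `CN1CCN(c2ccc(-c3cc4c(N5CCN(S(=O)(=O)C6CC6)CC5)ncnc4s3)cc2)CC1` and compound 3 `CCCNC(=O)N1CCN(c2ncnc3sc(-c4ccc(N5CCN(C)CC5)cc4)cc23)CC1`. In a functional assay on MDA-MB-231 cells (Homo sapiens) for antiproliferative activity, read by MTT assay, with a stated time of 48 h (a higher number here means a weaker inhibitor, a lower number a stronger inhibitor), compound 1 gives 5900 nM, compound 2 gives 11500 nM and compound 3 gives 8330 nM. Compound 3 holds the middle number of the three, but it cannot be separated from either of the others: a 1.4-fold higher number from compound 1 to compound 3 (0.15 log units; within the scatter) and a 1.4-fold lower number from compound 2 to compound 3 (0.14 log units; within the scatter).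

Compound 4 `CN1CCN(c2ccc(-c3cc4c(N5CCN(C(=O)Nc6ccc(C#N)cc6)CC5)ncnc4s3)cc2)CC1` is reached from compound 3 by one change: 4-cyanophenyl in place of propyl on an amide-type nitrogen. In words, 4-cyanophenyl stands in place of propyl on an amide-type nitrogen.

Within the data shown here, no measured step makes this exact change, so the evidence is indirect. Exchanges on the ring amine nitrogen have so far stayed small: a 1.9-fold higher number from compound 1 to compound 2 (0.29 log units; within the scatter) and a 1.4-fold higher number from compound 1 to compound 3 (0.15 log units; within the scatter). Only compound 1 carries an aromatic ring in that group, and its value of 5900 nM stays within the scatter of the other two, which gives only a weak hint of direction. A small move toward a lower number is expected, with no step beyond the scatter. The estimated step is a 1.5-fold lower number from compound 3 to compound 4 (0.18 log units; within the scatter). Among the measured compounds shown here, the range is kept wide since no aryl carbamoyl compound has been measured. For compound 4 the expected value is 5500 nM, with an estimated range of 2000 nM to 14000 nM.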

Compound 4, half-maximal inhibitory concentration: 3930 nM
The estimate for compound 4 lay 1.4-fold (0.15 log units) above the measured number; the measured number falls inside the stated range.
By their numbers in this assay, from the lowest: compounds 4, 1, 3 and 2 (each within the scatter of the next, the first and the last beyond it).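

In this assay, among these compounds, the exchange of propyl for 4-cyanophenyl on the amide-type nitrogen, with the carbonyl kept, gives a 2.1-fold lower number from compound 3 to compound 4 (0.33 log units; beyond the scatter) as a modest step and the first single exchange in this group to lie beyond the scatter. On the ring amine nitrogen, (4-cyanophenyl)carbamoyl in place of cyclopropylsulfonyl gives a 2.9-fold lower number from compound 2 to compound 4 (0.47 log units; beyond the scatter) as a second modest step, while in place of (2-phenylethenyl)sulfonyl it gives a 1.5-fold lower number from compound 1 to compound 4 (0.18 log units; within the scatter) and so no separation. An aromatic ring in this group is therefore not enough for a separation from both non-aromatic groups: compound 1 goes against that reading, as it stays within the scatter of compound 2 and of compound 3. No measurement on hand accounts for these steps.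

The entering group brings both a six-membered aromatic ring and a nitrile, and the compounds shown do not tell which of the two goes with the step. A plain phenyl on the same nitrogen would divide the two, and a benzyl or a longer chain such as hexyl would show whether the ring itself matters.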